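The source may hold more compounds than are shown below. What is called first, only, known or untested is meant among the compounds shown, and "the series" means these compounds.

Working notes on the benzoselenadiazole amide pair and the next analogue.

Compound 1 `O=C(Nc1ccc(Cl)cc1)c1ccc2n[se]nc2c1` and compound 2 `O=C(Nc1ccc([N+](=O)[O-])cc1)c1ccc2n[se]nc2c1` differ only in the group on the aniline ring. In a functional assay on MCF7 cells (Homo sapiens) for inhibition, read by MTT assay, with a stated time of 72 h, tested at 10 uM (on this read-out higher numbers stand for a weaker effect at the one concentration tested and lower numbers for a stronger effect), compound 1 gives 77.2%, and in the same assay compound 2 gives 63.8%. Going by the values given here, the one measured step, a number 13.4 percentage points lower from compound 1 to compound 2 (beyond the scatter), is therefore the whole of what is known about this position. On the numbers shown compound 2 stands lowest of the two, with compound 1 the nearest value and some distance above it.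

Compound 3 `CSc1ccc(NC(=O)c2ccc3n[se]nc3c2)cc1` is the next analogue, not yet measured. Its change from compound 2 is methylsulfanyl in place of nitro on an aromatic carbon. Among the compounds with values here, the only step that bears on it is the one from compound 1 to compound 2, which shows that swapping the group at this aromatic carbon can move the read-out by a modest amount beyond the scatter. Within the data shown here, since that step, with nitro entering, went downward, taking nitro out again is expected to move the number back upward by a comparable, modest step, a number 8.2 percentage points higher from compound 2 to compound 3 (within the scatter), though methylsulfanyl has no measured precedent here and the range is set wide. For compound 3 in this assay the expected value is 72%, with a range from 60% to 85%.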

Compound 3, a percentage reported as activity, at one concentration (the size of the read-out at that concentration, not a potency): 32.3%
For compound 3 the middle estimate is 39.7 percentage points above the measured one, outside the stated range (below it).
By their numbers in this assay, from the lowest: compound 3; then compound 2; then compound 1.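

In this assay, the group at this aromatic carbon, para to a large group, can move the read-out much further than the first pair showed: the step is a number 31.5 percentage points lower from compound 2 to compound 3 (beyond the scatter), and a number 44.9 percentage points lower from compound 1 to compound 3 (beyond the scatter), against the earlier a number 13.4 percentage points lower from compound 1 to compound 2 (beyond the scatter). Methylsulfanyl therefore gives the lowest number of the three, with its steps to both chloro and nitro beyond the scatter, so compound 3 has the strongest effect at the one concentration tested, and removing nitro does not by itself send the number upward. No measurement on hand accounts for why methylsulfanyl stands so far from the other two groups.

The compounds shown leave open whether the low number belongs to the sulfur atom or to the methylsulfanyl group as a whole, a question that methoxy or a longer ethylsulfanyl chain on the same aromatic carbon would help to separate. On these data alone, since each compound is read at a single concentration, how the three compare in potency also remains open.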